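The compounds below may be only part of what the source reports. "The series", "measured", "known", "first", "only" and "open" are said of these compounds alone.

Within the data shown here, in a functional assay on HeLa cells (Homo sapiens) for inhibition, read by CCK-8 assay, with a stated time of 48 h (a higher number here means a weaker inhibitor, a lower number a stronger inhibitor), compound 1 `Cc1cc(C)cc(NC(=O)NCCNS(=O)(=O)c2ccc(-c3ccccc3Oc3ccc([N+](=O)[O-])c([N+](=O)[O-])c3)s2)c1` gives 12000 nM and holds the only exact number so far. Compound 2 `Cc1cc(C)cc(NC(=O)NCCNS(=O)(=O)c2ccc(-c3ccccc3OCc3cccc(O)c3)s2)c1` stands at > 20000 nM in this assay, which is a limit and not a number. Compound 3 `Cc1cc(C)cc(NC(=O)NCCNS(=O)(=O)c2ccc(-c3ccccc3Oc3ccc(N)cc3)s2)c1` differs from compound 2 on an oxygen on an aromatic ring: 4-aminophenyl in place of 3-hydroxybenzyl on an oxygen on an aromatic ring is the change. Among the measured compounds shown here, the only measured step at this place is an at least 1.6-fold higher number from compound 1 to compound 2 (0.22 log units; that floor lies within the scatter) and its floor shows no large change, so no step beyond the scatter is expected in this assay here. The estimated step is an at least 1.2-fold lower number from compound 2 to compound 3 (0.09 log units; that floor lies within the scatter) in size and direction. Compound 3 is expected at 16000 nM with an estimated range of 7000 nM to 30000 nM in this assay.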

Compound 3, half-maximal inhibitory concentration: > 20000 nM
Compound 3 was reported as a limit (the forecaster's own chance of this, stated with the estimate: 45%); middle value at least 1.2-fold (0.09 log units) from the limit.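

In this assay, compound 3 is reported only as a limit, so a second group on this oxygen, 4-aminophenyl, also yields no exact number. Putting 4-aminophenyl in place of 3,4-dinitrophenyl gives an at least 1.6-fold higher number from compound 1 to compound 3 (0.22 log units; that floor lies within the scatter), so no change beyond the scatter is shown. The step between compound 2 and compound 3 cannot be read, because both values are limits: the limit of > 20000 nM in this assay, at which 2 of the 3 values shown sit.

On these data alone, whether a plain phenyl or a methyl on this oxygen would give an exact number stays open. So does the effect of a carboxylic acid on this ring.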